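Shifting the halogen on the aryl thiazole amine

The compounds below may be only part of what the source reports. "The series", "measured", "known", "first", "only" and "open" are said of these compounds alone.

Two compounds share a core and differ only on the aryl ring attached to it. Compound 1 `CSc1cccc(Nc2nc(-c3ccc(C#N)cc3)cs2)c1` gives 34000 nM in an assay on CFBE41o cells for positive allosteric modulation of Cystic fibrosis transmembrane conductance regulator variant F508del (Homo sapiens), with stated times of 30 min and 24 h; a higher number here means that more compound is needed for the effect, a lower number that less compound is needed. Compound 2 `CSc1cccc(Nc2nc(-c3ccc(F)cc3)cs2)c1` gives 27000 nM in this assay, and the step of a 1.3-fold lower number from compound 1 to compound 2 (0.10 log units; within the scatter) leaves the two standing together, with nothing separating them beyond the scatter. Compound 3 `CSc1cccc(Nc2nc(-c3cccc(Cl)c3)cs2)c1` has not been measured; it carries 3-chlorophenyl in place of 4-fluorophenyl on an aromatic carbon. Within the data shown here, the only measured step, the one from compound 1 to compound 2, swapped one group for another on the same ring and moved nothing beyond the scatter, so it bears on this change only loosely: a halogen is kept, but its name on the ring is different. On that footing no step beyond the scatter is expected for compound 3, and the estimated step of no change at the digits printed from compound 2 to compound 3 (within the scatter) is essentially flat. Compound 3 is therefore expected to give about 27000 nM in this assay, within a range of 11000 nM to 65000 nM.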

Compound 3, half-maximal effective concentration: 53000 nM
Estimate against measurement, compound 3: 2.0-fold (0.29 log units) below; measured number inside the range.
By their numbers in this assay, from the lowest: compounds 2, 1 and 3 (each within the scatter of the next).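

Exchanging 4-fluorophenyl for 3-chlorophenyl on the shared core gives a 2.0-fold higher number from compound 2 to compound 3 (0.29 log units; within the scatter) in this assay. Where the earlier step changed only the group carried on the aryl ring, this one changes both the halogen and its numbered place in the ring's name, and compound 3 still lies within the scatter of its nearest neighbour, so the three compounds form a single run with no break beyond the scatter. No evidence is available that would explain this result.

Going by these compounds, because halogen and place change together in this one step, their separate contributions stay open, and 4-chlorophenyl or 3-fluorophenyl would be needed to pull them apart. Also open, on these data alone, is how this position would respond to an aryl ring carrying an amine or a carboxylic acid instead of a halogen.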